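This account rests on a few compounds, and the source may have more. Where it says the series, first, only, none or still open, it means among the compounds named here.

Measured compounds and their values:

compound 1, `CCCOC(=O)c1[nH]cc(C(=O)OC(C)C(C)(C)C)c1C`: 4 nM
compound 2, `CCCOC(=O)c1[nH]c(C=O)c(C(=O)OC(C)(C)C)c1C`: 2000 nM
compound 3, `Cc1c(C(=O)OC(C)C(C)(C)C)c[nH]c1C(=O)Oc1cccnc1`: 720 nM

All three were tested in an assay on CHO cells for inhibition of metabotropic glutamate receptor 1 (Rattus norvegicus); a lower number here means a stronger inhibitor, a higher number a weaker inhibitor. Compound 2 stands at the highest of the three numbers, so it is the weakest inhibitor shown. Compound 3 comes nearest to it with a lower number, and compound 1 lies furthest away with a far lower number, the difference in each case being beyond the scatter of the assay.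

The unmeasured compound 4, `CCCOC(=O)c1[nH]c(CO)c(C(=O)OC(C)(C)C)c1C`, keeps everything in compound 2 except one group: hydroxymethyl in place of formyl on an aromatic carbon. Among the compounds with values here, the only single-point step among the measured compounds is a 180-fold higher number from compound 1 to compound 3 (2.26 log units; beyond the scatter), which concerns the ester oxygen rather than the ring carbon changed here, so it offers no direct guide. Within the data shown here, no measured pair shows what exchanging formyl for hydroxymethyl does in this assay.

Among the measured compounds shown here, with no precedent, the expectation for compound 4 is a number close to that of compound 2, with the step from compound 2 to compound 4 expected to stay within the scatter, a 1.4-fold lower number from compound 2 to compound 4 (0.15 log units; within the scatter). The estimate for compound 4 in this assay is 1400 nM, expected to lie between 400 nM and 5000 nM.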

Compound 4, half-maximal inhibitory concentration: 7900 nM
The estimate for compound 4 lay 5.6-fold (0.75 log units) below the measured number, outside the stated range (above it).
By their numbers in this assay, from the lowest: compound 1; then compound 3; then compound 2; then compound 4.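

In this assay hydroxymethyl in place of formyl on this aromatic carbon, next to the ring nitrogen and next to the ring atom that bears a tert-butoxycarbonyl group, gives a 4.0-fold higher number from compound 2 to compound 4 (0.60 log units; beyond the scatter) and so a weaker inhibitor. This is the first step shown at this ring carbon, since the earlier step concerned an ester oxygen, and it shows that this position responds to an exchange between two groups with the same count of heavy atoms. Formyl brings a double bond outside the aromatic ring, hydroxymethyl brings a hydrogen-bond donor, and no measurement here tells which of these differences, if either, accounts for the step.

Still open, going by these compounds, is how other groups on the same carbon would behave, such as a carboxylic acid, an aminomethyl group or a plain methyl group. Also open, on these data alone, is whether the exchange of formyl for hydroxymethyl would give a step of similar size with a different ester in place of the tert-butoxycarbonyl group or the propoxycarbonyl group.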